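From compound 2 to compound 4: the carbonyl substituent

The source may hold more compounds than are shown below. What is called first, only, known or untested is meant among the compounds shown, and "the series" means these compounds.

For the measured compounds named here, in a functional assay on MGC-803 cells (Homo sapiens) for inhibition, read by MTT assay, with a stated time of 48 h (a higher number here means a weaker inhibitor, a lower number a stronger inhibitor), compound 2 (`COc1ccc(CN(C(=O)C(C)Br)c2cc(OC)c(OC)c(OC)c2)cc1O`) gives 120 nM, the only number so far. Compound 1 (`COc1cc(NCc2ccccc2)cc(OC)c1OC`) reads > 80000 nM, which is a limit of the assay. Compound 3 (`COc1cc(NCc2ccc(Br)cc2)cc(OC)c1OC`) reads > 80000 nM, also a limit.

The next compound is compound 4 (`C/C=C/C=C/C(=O)N(Cc1ccc(OC)c(O)c1)c1cc(OC)c(OC)c(OC)c1`), with the difference (penta-1,3-dien-1-yl in place of 1-bromoethyl on a carbonyl carbon). Penta-1,3-dien-1-yl thus stands in place of 1-bromoethyl on a carbonyl carbon, and the rest of the structure is unchanged.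

Going by the values given here, the only measured step, a step that the two limits leave unreadable from compound 1 to compound 3, is a bromo in place of hydrogen on an aromatic carbon. It gives no size to carry over and does not involve this substituent. Among the compounds with values here, no measured step therefore bears directly on the change, and the expectation is only loosely anchored on compound 2 at 120 nM, the sole numeric reference. A loss is expected rather than a gain, with the estimated move being a 21-fold higher number from compound 2 to compound 4 (1.32 log units; beyond the scatter) in this assay. The estimate for compound 4 is 2500 nM, with an expected range of 250 nM to 25000 nM.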

Compound 4, half-maximal inhibitory concentration: 140 nM
Compound 4: middle estimate off by 18-fold (1.25 log units), on the high side, outside the stated range (below it).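

The new step is a 1.2-fold higher number from compound 2 to compound 4 (0.07 log units; within the scatter) in this assay and gives the first readable size for a change on this carbonyl carbon. Penta-1,3-dien-1-yl, with 5 carbon atoms and 2 double bonds outside aromatic rings, replaces 1-bromoethyl with no shift beyond the scatter. For this pair, then, the bromine of the 1-bromoethyl group is not required for a value of this order, although the pair does not show why.

Open, as far as these compounds go, is how an amine, a carboxylic acid or a longer saturated chain on this carbonyl carbon would read against compound 2 and compound 4. The step from compound 1 to compound 3 cannot be read, so the effect of bromo on the aromatic carbon also stays open, with both values resting on a limit: the limit of > 80000 nM in this assay, at which 2 of the 4 values shown sit.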